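Carbamate to urea on a tetrahydroquinoline sulfonamide core

A few compounds are considered here, and "the series" means these few. Any claim that something is new, unique, unknown or untested is made for them only; others in the source may bear on it.

For the measured compounds named here, compound 1 `CCOC(=O)N1CCCc2cc(S(=O)(=O)N3CC(c4ccccc4)NC3=O)ccc21` is the only member of this set with a number: in a functional assay on A549 cells (Homo sapiens) for antiproliferative activity, read by MTT assay (on this read-out lower numbers stand for stronger inhibition and higher numbers for weaker inhibition), compound 1 gives 344 nM. Compound 2 `O=C(CCl)N1CCCc2cc(S(=O)(=O)N3CC(c4ccccc4)NC3=O)ccc21` shares the core, but in this assay compound 2 gives "not determined" (no result reported). Compound 3 `O=C(NC1CCCCC1)N1CCCc2cc(S(=O)(=O)N3CC(c4ccccc4)NC3=O)ccc21` differs from compound 1 in one place: cyclohexylamino in place of ethoxy on a carbonyl carbon. Going by the values given here, no measured pair shows what such a change does, so the step from compound 1 to compound 3 is expected to stay near the scatter, with no clear direction. On that basis the expected step is a 1.2-fold higher number from compound 1 to compound 3 (0.07 log units; within the scatter). For compound 3 the estimate in this assay is 400 nM, within 150 nM to 1200 nM.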

Compound 3, half-maximal inhibitory concentration: 231 nM
For compound 3 the middle estimate is 1.7-fold (0.24 log units) above the measured one, and the stated range covers the measured number.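

Cyclohexylamino in place of ethoxy on a carbonyl carbon gives a 1.5-fold lower number from compound 1 to compound 3 (0.17 log units; within the scatter) in this assay, the first measured step at this position. The carbonyl carbon thus carries either group, one with a six-membered ring and a hydrogen-bond donor, without a change beyond the scatter. Going by these compounds, whether methylamino, phenylamino or a longer open chain such as butylamino on the same carbonyl carbon would also stay within the scatter remains open. Nothing measured on these compounds offers an explanation for this result.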